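A Furan-to-Thiophene Swap at Low Inhibition

The source may hold more compounds than are shown below. What is called first, only, known or untested is meant among the compounds shown, and "the series" means these compounds.

For the measured compounds named here, compound 2 `CC1=C(C(=O)OCC2CCC2)C(c2ccco2)NC(=O)N1` gives 1% in an assay on membranes from HeLa cells for displacement of a labelled ligand from adenosine receptor A3 (Homo sapiens), read by scintillation counting, with a stated time of 180 min, tested at 1 uM (a higher number here means more inhibition at the concentration tested (going by the name of the read-out), a lower number less inhibition), the lower of the two numbers measured so far. Its nearest neighbour, compound 1 `CCCC(=O)C1=C(C)NC(=O)NC1c1cccs1`, gives 2% in this assay, a value within the scatter of compound 2, so no order between the two can be read. Compound 3 `CC1=C(C(=O)OCC2CCC2)C(c2cccs2)NC(=O)N1` differs from compound 2 in one place: thiophen-2-yl in place of furan-2-yl on a saturated ring carbon. Because compound 1 with its thiophen-2-yl gives 2% within the scatter of compound 2, a step of a number 2 percentage points higher from compound 2 to compound 3 (within the scatter) is expected, none beyond the scatter. Compound 3 is estimated at 3%, between -8% and 14%.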

Compound 3, a percentage reported as inhibition, at one concentration (the size of the read-out at that concentration, not a potency): 1%
Beside the measured number, compound 3's estimate is 2 percentage points above it; the range from low to high includes it.
By their numbers in this assay, from the lowest: compounds 2, 3 and 1 (each within the scatter of the next).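

In this assay, for the compounds shown here, thiophen-2-yl in place of furan-2-yl on a saturated ring carbon gives no change at the digits printed from compound 2 to compound 3 (within the scatter), the first direct reading of this position, and it shows no order between the two rings. Cyclobutylmethoxy in place of propyl on a carbonyl carbon gives a number 1 percentage points lower from compound 1 to compound 3 (within the scatter), so that change also shows no order. No measurement on hand offers an explanation for these numbers.

All three compounds sit within the scatter of each other, so neither place has yet shown any effect on the read-out. As far as these compounds go, whether an amine on that saturated ring carbon, or a carboxylic acid or a longer chain on the carbonyl carbon, would move the number beyond the scatter stays open.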